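Amide substituent size and the nuclear factor activation read-out

The source may hold more compounds than are shown below. What is called first, only, known or untested is meant among the compounds shown, and "the series" means these compounds.

Compound 2 `CN(C)C(=O)c1cccc(-c2cccc(-n3ncc(C(=O)O)c3C3CC3)c2)c1F` is the tertiary amide carrying dimethylamino on the carbonyl carbon; in an assay on BEAS-2B cells for activation of nuclear factor erythroid 2-related factor 2 (Homo sapiens), read by MTT assay, with a stated time of 48 h (on this read-out lower numbers stand for an effect already at smaller amounts and higher numbers for an effect only at larger amounts of compound), compound 2 gives 1300 nM. Compound 1 `O=C(O)c1cnn(-c2cccc(-c3cccc(C(=O)N4CCCC5(CCCC5)C4)c3F)c2)c1C1CC1` carries the larger spirocyclic amine on the same carbonyl; in this assay compound 1 gives 3700 nM. Within the data shown here, compound 2 thus stands at the lowest of the two numbers so far, and the only step in hand is a 2.8-fold lower number from compound 1 to compound 2 (0.45 log units; beyond the scatter), where a smaller amide substituent went with a modestly lower number.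

Compound 3 `O=C(O)c1cnn(-c2cccc(-c3cccc(C(=O)N4CCCCC4)c3F)c2)c1C1CC1` is not yet measured. The change from compound 2 is piperidin-1-yl in place of dimethylamino on a carbonyl carbon. Among the measured compounds shown here, it is the reverse direction of the one step available, though the group entering is smaller than the group that left in compound 1. Because a 2.8-fold lower number from compound 1 to compound 2 (0.45 log units; beyond the scatter) pointed downward when the amide substituent shrank, the expected direction for compound 3 is a modest rise in the number, of a size that may or may not clear the scatter.

Compound 3 is therefore expected at 2200 nM, with a range of 1000 nM to 5000 nM; the step expected is a 1.7-fold higher number from compound 2 to compound 3 (0.23 log units; within the scatter).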

Compound 3, half-maximal effective concentration in the nuclear factor erythroid 2-related factor 2 assay: 2300 nM
Estimate against measurement, compound 3: 1.0-fold (0.02 log units) below; the range from low to high includes it.
By their numbers in the nuclear factor erythroid 2-related factor 2 assay, from the lowest: compounds 2, 3 and 1 (each within the scatter of the next, the first and the last beyond it).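

Among these compounds, in the nuclear factor erythroid 2-related factor 2 assay, the new compound splits the one step beyond the scatter, a 2.8-fold lower number from compound 1 to compound 2 (0.45 log units; beyond the scatter), into two steps within it: a 1.8-fold higher number from compound 2 to compound 3 (0.25 log units; within the scatter), and a 1.6-fold lower number from compound 1 to compound 3 (0.21 log units; within the scatter). On the carbonyl carbon, piperidin-1-yl in place of dimethylamino therefore gives no readable change in this read-out, although the larger change from compound 1 to compound 2 does. In a physicochemical assay for lipophilicity, read by HPLC, at pH 2 (a lower number here means a more polar compound, a higher number a more lipophilic compound), compound 2 gives 1.3 and compound 3 gives 2.3, so with no step beyond the scatter in the nuclear factor erythroid 2-related factor 2 assay, this same change does raise lipophilicity in the physicochemical assay: the measured distribution coefficient of compound 2, 1.3, and of compound 3, 2.3, a number 1.00 log units higher (beyond the scatter)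

The compounds shown leave open whether the number in the nuclear factor erythroid 2-related factor 2 assay follows the heavy atom count of the amine group, its measured distribution coefficient or neither, as the only pair with both read-outs changes both together and its step in the first of these stays within the scatter. A morpholin-4-yl group or a 4-hydroxypiperidin-1-yl group on the same carbonyl carbon, which keeps the six-membered ring but adds oxygen, lies outside the compounds shown, so how this position responds to such a group remains unknown.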